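A Cyclopropyl Variant of Compound 2

The compounds below may be only part of what the source reports. "The series", "measured", "known", "first", "only" and "open" are said of these compounds alone.

Compound 2 `COc1nc2ccc(Br)cc2cc1C(c1ccccc1)n1cc(-c2ccc(F)cc2)nn1` was tested in an ADME assay on SK-OV-3 cells (Homo sapiens) for cytotoxicity, read by sulforhodamine B assay, with a stated time of 48 h, tested at 10 uM (a higher number here means more inhibition at the concentration tested (going by the name of the read-out), a lower number less inhibition), where compound 2 gives 14.3%. Going by the values given here, only one other compound has been measured, compound 1 `CCCCCc1cn(C(c2ccccc2)c2cc3cc(Br)ccc3nc2OC)nn1`, which in this assay gives 10.5%. The step of a number 3.8 percentage points higher from compound 1 to compound 2 (within the scatter) leaves the two numbers within the scatter, so compound 2 stands together with compound 1 at a low level of inhibition. Compound 3 `COc1nc2ccc(Br)cc2cc1C(c1ccccc1)n1cc(C2CC2)nn1` differs from compound 2 in one place: cyclopropyl in place of 4-fluorophenyl on an aromatic carbon. Among the compounds with values here, no measured step bears directly on this exchange; the only measured step, from pentyl to 4-fluorophenyl on the same aromatic carbon, was small. With both measured values low and that step within the scatter, compound 3 is expected to remain near the same level, the expected step of a number 3.3 percentage points lower from compound 2 to compound 3 (within the scatter) amounting to no change beyond the scatter. The estimate for compound 3 is 11%, ranging from 2% to 24%.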

Compound 3, a percentage reported as inhibition, at one concentration (the size of the read-out at that concentration, not a potency): 3.52%
Compound 3: the middle estimate sits 7.5 percentage points above what was measured, and the stated range covers the measured number.
By their numbers in this assay, from the lowest: compounds 3, 1 and 2 (each within the scatter of the next, the first and the last beyond it).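

In this assay, going by these compounds alone, the aromatic carbon of the five-membered ring proves to be a place where exchanging one group can move the number beyond the scatter: cyclopropyl in place of 4-fluorophenyl gives a number 10.8 percentage points lower from compound 2 to compound 3 (beyond the scatter) and is the first such step. Cyclopropyl in place of pentyl gives a number 7 percentage points lower from compound 1 to compound 3 (within the scatter) and stays within the scatter, so the change separates only compound 2 and compound 3, and the size of the step depends on which group leaves. Nothing available explains why these two exchanges differ.

As far as these compounds go, whether a plain phenyl, a longer chain or a carboxylic acid at this place would stand with compound 2 or with compound 3 remains open. Also open, from the compounds shown here alone, is whether any group on this carbon can lift the number well clear of these low values.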